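The source may hold more compounds than are shown below. What is called first, only, known or untested is meant among the compounds shown, and "the series" means these compounds.

Of the compounds shown here, three have been measured in an assay on L1210 cells for inhibition of Thymidylate synthase (Mus musculus); on this read-out lower numbers stand for stronger inhibition and higher numbers for weaker inhibition. Compound 1, `C#CCN(Cc1ccc2nc(C)nc(O)c2c1)c1ccc(C(=O)N[C@@H](CCC(=O)O)C(=O)N(C)[C@@H](CCC(=O)O)C(=O)O)cc1`, gives 11 nM. Compound 2, `C#CCN(Cc1cc2c(O)nc(C)nc2cc1C)c1ccc(C(=O)N[C@@H](CCC(=O)O)C(=O)N(C)[C@@H](CCC(=O)O)C(=O)O)c(F)c1`, gives 1.1 nM, and compound 3, `C#CCN(Cc1ccc2nc(C)nc(O)c2c1)c1ccc(C(=O)N[C@@H](CC(C)(C)C(=O)O)C(=O)N[C@@H](CCC(=O)O)C(=O)O)cc1`, gives 18 nM. Within this set compound 2 stands lowest, and so shows the strongest inhibition: compound 1 sits clearly higher, a gap that lies beyond the usual scatter, and compound 3 sits higher still, also beyond the scatter. None of these three pairs differs in only one place, so no single structural step can be read from the measured compounds alone.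

Compound 4, `C#CCN(Cc1cc2c(O)nc(C)nc2cc1C)c1ccc(C(=O)N[C@@H](CCC(=O)O)C(=O)N(CC#C)[C@@H](CCC(=O)O)C(=O)O)c(F)c1`, is the compound still to be measured. It differs from compound 2 in one place only: ethynyl in place of hydrogen on a saturated chain carbon bound to an amide-type nitrogen. In other words, the methyl group on the amide-type nitrogen of the dipeptide part becomes a propargyl group, and everything else in the molecule is unchanged.

Among the compounds with values here, no measured pair shows what such a change does here, so the expectation rests on compound 2 alone. The change is small and sits away from the parts that differ between the measured compounds, so only a step within or just beyond the scatter is expected, if anything toward weaker inhibition. The step from compound 2 to compound 4 in this assay is expected to be a 2.0-fold higher number from compound 2 to compound 4 (0.30 log units; within the scatter). Compound 4 is therefore estimated at 2.2 nM, with a range from 0.7 nM to 8 nM.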

Compound 4, inhibition constant: 0.21 nM
Compound 4: the middle estimate sits 10-fold (1.02 log units) above what was measured; measured number outside the range, below it.
By their numbers in this assay, from the lowest: compound 4; then compound 2; then compounds 1 and 3 (each within the scatter of the next).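

In this assay, putting a propargyl group in place of the methyl on the amide-type nitrogen gives a 5.2-fold lower number from compound 2 to compound 4 (0.72 log units; beyond the scatter), a step beyond the scatter and toward stronger inhibition. The earlier compounds shown here could not show this, as none of them formed a pair differing in one place; this pair shows that the substituent on this nitrogen of the dipeptide part can shift the read-out on its own, and that the longer propargyl group is accepted here without any loss of inhibition. Nothing given here explains why the number falls, and a single pair sets no general rule for this position.

The compounds shown leave open whether the triple bond matters or only the longer chain, a question that an ethyl or propyl group on this nitrogen would help to settle, and how a plain amide hydrogen at the same place would compare. As far as these compounds go, it also remains open whether the change from methyl to propargyl would give a similar step on the core of compound 1.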